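The compounds below may be only part of what the source reports. "The series", "measured", "known", "first", "only" and "open" are said of these compounds alone.

Going by the values given here, compound 1 `CCN(CC)CCNC(=O)c1ccc(C(CC)(CC)c2ccc(OCC(O)C(C)(C)C)c(C)c2)n1CC` gives 110 nM in an assay on HL-60 cells for agonist activity at vitamin D3 receptor (Homo sapiens), read by microscopy, with a stated time of 96 h (a higher number here means that more compound is needed for the effect, a lower number that less compound is needed), the only outright number in the set. Compound 2 `CCn1c(C(=O)Nc2ccc(OC(F)(F)F)cc2)ccc1C(CC)(CC)c1ccc(OCC(=O)C(C)(C)C)c(C)c1` gives only a limit in this assay, namely > 50000 nM, which is the limit of > 50000 nM in this assay, at which 1 of the 2 values shown sits. Compound 3 `CCn1c(C(=O)Nc2cccc(C(F)(F)F)c2)ccc1C(CC)(CC)c1ccc(OCC(O)C(C)(C)C)c(C)c1` keeps the hydroxylated side chain of compound 1 and carries the change (3-(trifluoromethyl)phenyl in place of 2-(diethylamino)ethyl on an amide-type nitrogen). Compound 2 differs from compound 1 in two places, so its limit cannot be tied to the amide substituent alone. Compound 3 is expected to be weaker, with the step of a 27-fold higher number from compound 1 to compound 3 (1.44 log units; beyond the scatter) estimated as a clear loss. The estimate for compound 3 is 3000 nM, between 300 nM and 50000 nM, with a real chance that only a limit is returned.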

Compound 3, half-maximal effective concentration: > 50000 nM
Compound 3: only a limit was reported; the forecaster's own chance of this, stated with the estimate: 30%; middle value at least 16-fold (1.22 log units) from the limit.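

With the hydroxylated side chain kept, 3-(trifluoromethyl)phenyl in place of 2-(diethylamino)ethyl on the amide-type nitrogen gives an at least 450-fold higher number from compound 1 to compound 3 (2.65 log units; beyond the scatter) in this assay. This single change is therefore enough for a large loss, which compound 2, differing from compound 1 in two places, could not show. The value of compound 3 is a limit, not a number, so the full size of the step stays unknown: the limit of > 50000 nM in this assay, at which 2 of the 3 values shown sit.

From the compounds shown here alone, whether the loss follows from removing the diethylamino group or from introducing the aryl ring remains open. A morpholine, a carboxylic acid or a longer aminoalkyl chain on this nitrogen would help separate the two.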